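Ethyl Ester to Free Acid on a Shared Core

A few compounds are considered here, and "the series" means these few. Any claim that something is new, unique, unknown or untested is made for them only; others in the source may bear on it.

Compound 1, `CNC(=O)/C=C/c1ccncc1-c1ccc2ccccc2c1`: 12.4 nM in an assay on a protein complex for inhibition of CDK8/Cyclin C (Homo sapiens), with a stated time of 1 h; on this read-out lower numbers stand for stronger inhibition and higher numbers for weaker inhibition
Compound 2, `O=C(O)[C@@H]1CCCN1C(=O)/C=C/c1ccncc1-c1ccc2ccccc2c1`: "not determined" (no result reported) in this assay
Compound 3, `CCOC(=O)/C=C/c1ccncc1-c1ccc2cc[nH]c2c1`: 12.1 nM in this assay

Two of the three measured compounds have a number, and compound 3 holds the lower of the two; compound 1, however, lies so close that the two cannot be told apart within the usual scatter, so neither can be called the stronger inhibitor. Compound 2 carries a carboxylic acid on a ring attached to the carbonyl, but no result was reported for it in this assay, so it adds nothing to the comparison.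

Compound 4, `O=C(O)/C=C/c1ccncc1-c1ccc2cc[nH]c2c1`, is the next compound to be measured. It differs from compound 3 in one place: hydrogen in place of ethyl on an oxygen next to a carbonyl group. Going by the values given here, no pair of measured compounds shows this same change, so the size of the step has to be judged from what is known. Compound 1 and compound 3 carry different groups on the carbonyl yet give near-identical numbers in this assay, which suggests this end of the molecule tolerates variation. A free acid is a larger departure than the swap seen so far, so a small weakening is expected, though one that may stay within the scatter.

Compound 4 is expected to give about 25 nM in this assay, estimated to fall between 8 nM and 80 nM. The expected step of a 2.1-fold higher number from compound 3 to compound 4 (0.32 log units; beyond the scatter) is therefore modest, toward a higher number.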

Compound 4, half-maximal inhibitory concentration: 2.4 nM
Estimate against measurement, compound 4: 10-fold (1.02 log units) above; the measured number lies below the stated range.
By their numbers in this assay, from the lowest: compound 4; then compounds 3 and 1 (each within the scatter of the next).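

Ethoxycarbonyl to carboxy is the first single change seen at this position, and in this assay it brings a 5.0-fold lower number from compound 3 to compound 4 (0.70 log units; beyond the scatter). Going by these compounds alone, until now, this end of the molecule offered no pair that differed in one place, so nothing showed how much a single change here could move the number. This pair shows that removing the ethyl, with its 2 heavy atoms, and leaving only a hydrogen on the oxygen next to the carbonyl group does not cost inhibition here, and that the free acid gives the lower number of the two; the data shown contain no measurement that would explain this step.

As far as these compounds go, it remains open whether the carboxylic acid itself is needed for the lower number, or whether a methyl ester, a primary amide or a tetrazole in the same place would give a similar result. Within the data shown here, also open is whether the same ethyl-to-hydrogen change would have a similar effect on the core of compound 1, where the only compound with a carboxylic acid, compound 2, has no reported number and carries that acid on a ring.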